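A few compounds are considered here, and "the series" means these few. Any claim that something is new, unique, unknown or untested is made for them only; others in the source may bear on it.

Values in a functional assay on CNE-2 cells (Homo sapiens) for cytotoxicity, read by MTT assay, with a stated time of 72 h; a lower number here means a stronger inhibitor, a higher number a weaker inhibitor:

Compound 1 `COc1cc2ncnc(NNC(=S)NC(=O)c3ccc(F)cc3)c2cc1OC`: 16100 nM
Compound 2 `O=C(NC(=S)NNc1ncnc2ccccc12)c1cccc(Cl)c1`: 2920 nM
Compound 3 `O=C(NC(=S)NNc1ncnc2ccccc12)c1ccccc1Cl`: 6090 nM

Compound 1 stands highest of the three numbers; compound 3 is nearest and compound 2 furthest, both lower and both beyond the scatter. Compound 4 `COc1cc2ncnc(NNC(=S)NC(=O)c3ccccc3OC)c2cc1OC` differs from compound 1 in one place: 2-methoxyphenyl in place of 4-fluorophenyl on a carbonyl carbon. Among the measured compounds shown here, no measured pair exchanges a 4-fluorophenyl for a 2-methoxyphenyl. For the measured compounds named here, the only step that moves a substituent around a phenyl on the carbonyl carbon is a 2.1-fold higher number from compound 2 to compound 3 (0.32 log units; beyond the scatter), on a different core and with a different substituent, so it bears only loosely. The expectation is therefore a small step, if any, leaning toward a higher number: compound 4 is estimated at 22000 nM (range 8000 nM to 60000 nM), an expected step of a 1.4-fold higher number from compound 1 to compound 4 (0.14 log units; within the scatter).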

Compound 4, half-maximal inhibitory concentration: 8410 nM
Beside the measured number, compound 4's estimate is 2.6-fold (0.42 log units) above it; measured number inside the range.
By their numbers in this assay, from the lowest: compound 2; then compounds 3, 4 and 1 (each within the scatter of the next, the first and the last beyond it).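

In this assay, the exchange of 4-fluorophenyl for 2-methoxyphenyl on a carbonyl carbon gives a 1.9-fold lower number from compound 1 to compound 4 (0.28 log units; within the scatter). Among the compounds shown here, this is the first reading of this position on the core of compound 1, and the two groups cannot be separated here, even with the added oxygen of the 2-methoxyphenyl. Nothing available bears on the reason for this result.

Open, from the compounds shown here alone, is whether an amine, a carboxylic acid or a longer alkoxy chain such as butoxy on the phenyl would move the number beyond the scatter. Also open, going by these compounds, is whether 2-methoxyphenyl behaves alike on the core of compound 2.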